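A few compounds are considered here, and "the series" means these few. Any claim that something is new, unique, unknown or untested is made for them only; others in the source may bear on it.

Compound 2 `O=C(NCCO)c1cc2ccc(OCc3cccc(Br)c3)cc2oc1=O` carries a 3-bromophenyl where compound 1 `CCOc1ccc2cc(C(=O)NCCO)c(=O)oc2c1` carries a methyl on a saturated chain carbon bound to an oxygen on an aromatic ring. In a functional assay on HeLa cells (Homo sapiens) for cytotoxicity, read by MTT assay, with a stated time of 72 h (a higher number here means a weaker inhibitor, a lower number a stronger inhibitor), compound 1 reaches only a limit, > 100000 nM, which is the limit of > 100000 nM in this assay, at which 1 of the 2 values shown sits. In this assay, among the measured compounds shown here, compound 2 gives 17600 nM, the only actual number among the two values shown. For the measured compounds named here, the step of an at least 5.6-fold lower number from compound 1 to compound 2 (0.75 log units; beyond the scatter) is the single measured comparison, and it shows that an aryl group at this position brought the number down.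

Compound 3 `O=C(NCCO)c1cc2ccc(OCc3ccc([N+](=O)[O-])cc3)cc2oc1=O` differs from compound 2 by 4-nitrophenyl in place of 3-bromophenyl on a saturated chain carbon bound to an oxygen on an aromatic ring. Going by the values given here, no measured step sets one aryl group against another at this position; the only step, an at least 5.6-fold lower number from compound 1 to compound 2 (0.75 log units; beyond the scatter), concerns methyl against 3-bromophenyl and bears on compound 3 only indirectly, by showing that an aryl group here is tolerated. One therefore expects no step beyond the scatter in this assay, with the direction uncertain. Compound 3 is estimated at 20000 nM, between 7000 nM and 60000 nM, which is expected to mean a step of a 1.1-fold higher number from compound 2 to compound 3 (0.06 log units; within the scatter).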

Compound 3, half-maximal inhibitory concentration: 6890 nM
Estimate against measurement, compound 3: 2.9-fold (0.46 log units) above; measured number outside the range, below it.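

In this assay, the result shows that on a saturated chain carbon bound to an oxygen on an aromatic ring, the identity of the aryl group matters and not merely its presence: 4-nitrophenyl in place of 3-bromophenyl gives a 2.6-fold lower number from compound 2 to compound 3 (0.41 log units; beyond the scatter). Set against methyl, 4-nitrophenyl gives an at least 14-fold lower number from compound 1 to compound 3 (1.16 log units; beyond the scatter), so a second aryl group also lowers the number, and the earlier gain is not peculiar to 3-bromophenyl. That step rests on a limit for compound 1 and not on a number: the limit of > 100000 nM in this assay, at which 1 of the 3 values shown sits.

The change from compound 2 to compound 3 alters both the substituent on the phenyl ring and its numbered place, so these two compounds cannot say which of the two matters, and a 4-bromophenyl or a 3-nitrophenyl would be needed to separate them. From the compounds shown here alone, it also remains open whether an unsubstituted phenyl, or a ring carrying an amine or a carboxylic acid, would follow the same course, and whether a longer chain between the oxygen and the ring would keep the lower number.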